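This account rests on a few compounds, and the source may have more. Where it says the series, first, only, none or still open, it means among the compounds named here.

Measured compounds so far:

- compound 1, `O=C(CCCCCCN1C(=O)/C(=N\O)c2ccccc21)NO`, gives 790 nM in a functional assay on MCF7 cells (Homo sapiens) for antiproliferative activity, read by sulforhodamine B assay, with a stated time of 48 h; a lower number here means a stronger inhibitor, a higher number a weaker inhibitor
- compound 2, `O=C(CCCCCCN1C(=O)/C(=N\O)c2cc(F)ccc21)NO`, gives 1550 nM in this assay
- compound 3, `CO/N=C1/C(=O)N(CCCCCCC(=O)NO)c2ccccc21`, gives 1710 nM in this assay

Compounds 1 and 2 share one core and differ in a single place: fluoro in place of hydrogen on an aromatic carbon. This change gives a 2.0-fold higher number from compound 1 to compound 2 (0.29 log units; within the scatter), so the two values are not separated with confidence. Compound 3 carries a different core; the difference between the two cores is not broken down here. Compared with compound 2, compound 3 lies within the scatter; compared with compound 1, the gap lies beyond it, so the core of compound 3 reads as somewhat weaker in this assay on this single comparison, with no further compounds to test that.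

Compound 4, `CO/N=C1/C(=O)N(CCCCCCC(=O)NO)c2ccc(F)cc21`, has not been measured. It differs from compound 3 by fluoro in place of hydrogen on an aromatic carbon, which is the same change as that made from compound 1 to compound 2, at a place described in the same words. Among the measured compounds shown here, only that one earlier instance of the change exists, so any expectation for compound 4 in this assay rests on the step of a 2.0-fold higher number from compound 1 to compound 2 (0.29 log units; within the scatter) carried over to the core of compound 3. On that basis the step from compound 3 is expected to be a 1.6-fold higher number from compound 3 to compound 4 (0.21 log units; within the scatter), of a size comparable to the earlier one, with the range kept wide because a single precedent within the scatter does not fix direction firmly. Compound 4 is therefore estimated at 2800 nM, expected between 1400 nM and 5600 nM.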

Compound 4, half-maximal inhibitory concentration: 2420 nM
Estimate against measurement, compound 4: 1.2-fold (0.06 log units) above, within the range that was stated.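

In this assay, fluoro in place of hydrogen on an aromatic carbon gives a 1.4-fold higher number from compound 3 to compound 4 (0.15 log units; within the scatter), so on the core of compound 3, as on the core of compound 1, the two values are not separated with confidence. Set side by side, the two steps do not differ: the same change on two cores in this assay, a 2.0-fold higher number (0.29 log units; within the scatter) from compound 1 to compound 2 and a 1.4-fold higher number (0.15 log units; within the scatter) from compound 3 to compound 4, 1.4-fold (0.14 log units) apart, within the scatter of two such steps. The change therefore carries from one core to the other without a detectable difference in this read-out, but neither step alone lies beyond the scatter, so no real effect of fluoro is established on either core, and two instances in a single assay give no rule for any further core.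

The compounds shown leave open whether another group on the same aromatic carbon, such as chloro, methoxy or an amine, would give a step beyond the scatter, and whether fluoro elsewhere on the six-membered aromatic ring would match these two steps. They also leave open how a shorter or longer chain, or a carboxylic acid in place of the hydroxamic acid, would behave on either core.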